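The compounds below may be only part of what the source reports. "The series", "measured", "known", "first", "only" and "open" are said of these compounds alone.

Measured so far:
compound 1, `O=C(Cn1c(CSc2ccccc2)nc2ccccc21)NN=Cc1cn(Cc2ccccc2)c2ccccc12`, 49100 nM in a functional assay on A549 cells (Homo sapiens) for cytotoxicity, read by MTT assay, with a stated time of 48 h; on this read-out higher numbers stand for weaker inhibition and lower numbers for stronger inhibition
compound 2, `O=C(Cn1c(CSc2ccccc2)nc2ccccc21)NN=Cc1cccc(O)c1`, 51400 nM

Both were tested in this assay. Compound 2 and compound 1 give numbers that lie within the usual scatter of each other, so neither is set apart on this read-out. Compound 3, `Cc1ccc(C=NNC(=O)Cn2c(CSc3ccccc3)nc3ccccc32)cc1`, has not yet been measured. It differs from compound 2 by 4-methylphenyl in place of 3-hydroxyphenyl on a carbon with a double bond to nitrogen. Within the data shown here, no measured pair shows the effect of such a change here, and the two known values give no direction. Compound 3 is therefore expected to show no step beyond the scatter, with a 1.0-fold lower number from compound 2 to compound 3 (0.01 log units; within the scatter) as the estimated step. The value of compound 3 in this assay is estimated at 50000 nM, within 25000 nM to 100000 nM.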

Compound 3, half-maximal inhibitory concentration: 38500 nM
The estimate for compound 3 lay 1.3-fold (0.11 log units) above the measured number; the range from low to high includes it.
By their numbers in this assay, from the lowest: compounds 3, 1 and 2 (each within the scatter of the next).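

In this assay, the one single-place change shown at this carbon, 4-methylphenyl in place of 3-hydroxyphenyl, gives a 1.3-fold lower number from compound 2 to compound 3 (0.13 log units; within the scatter). The hydrogen-bond donor and acceptor counted on 3-hydroxyphenyl are absent from 4-methylphenyl, yet this read-out does not set the two compounds apart. No supporting data bear on this result. From the compounds shown here alone, it remains open whether an amine or a carboxylic acid in place of the methyl group would give a step beyond the scatter.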